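Quinolinequinone aminated analogues: from pyrrolidinyl to allylamino

The source may hold more compounds than are shown below. What is called first, only, known or untested is meant among the compounds shown, and "the series" means these compounds.

Measured so far:
compound 1 `O=C1C=C(N2CC2)C(=O)c2nc(-c3ccccc3)ccc21` with 85.1 nM in a functional assay on NCI60 cells (Homo sapiens) for cytotoxicity; a higher number here means a weaker inhibitor of growth, a lower number a stronger inhibitor of growth;
compound 2 `O=C1C(N2CCCC2)=CC(=O)c2nc(-c3ccccc3)ccc21` with 44700 nM.

Within the data shown here, compound 2 gives the highest of the two numbers in this assay; the only other value, that of compound 1, lies far lower, well beyond the scatter. Compound 3 `C=CCNC1=CC(=O)c2nc(-c3ccccc3)ccc2C1=O` differs from compound 2 by allylamino in place of pyrrolidin-1-yl on a double-bonded ring carbon. Among the measured compounds shown here, no step between measured compounds covers this change, so the expectation rests on the two values alone. A moderate step toward a lower number is expected, a 3.0-fold lower number from compound 2 to compound 3 (0.47 log units; beyond the scatter). Compound 3 is estimated at 15000 nM, within 3000 nM to 60000 nM.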

Compound 3, concentration for 50% growth inhibition: 1910 nM
Estimate against measurement, compound 3: 7.9-fold (0.90 log units) above, outside the stated range (below it).
By their numbers in this assay, from the lowest: compound 1; then compound 3; then compound 2.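

In this assay the exchange of pyrrolidin-1-yl for allylamino on the double-bonded ring carbon produces a large shift (a 23-fold lower number from compound 2 to compound 3 (1.37 log units; beyond the scatter)). This shows that the number at this position depends strongly on the amine group attached there. The entering group has no ring and adds a hydrogen-bond donor, but this single step cannot separate those two differences, and no measured evidence explains it.

From the compounds shown here alone, whether propylamino, which lacks the allyl double bond, would give a similar number remains open. So does the outcome with a ring amine bearing a hydrogen-bond donor, such as piperazin-1-yl.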